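Working notes: side-chain replacement at the dichloro-substituted ring

This account rests on a few compounds, and the source may have more. Where it says the series, first, only, none or still open, it means among the compounds named here.

Measured in an assay for inhibition of histone-lysine N-methyltransferase EZH2 variant Y641N (Homo sapiens), read by scintillation counting, with a stated time of 60 min, in the presence of a further agent that is not named here; a higher number here means a weaker inhibitor, a lower number a stronger inhibitor:
compound 1 `Cc1cc(C)c(CN2CCc3c(Cl)cc([C@H](CO)[C@H]4CCOC4)c(Cl)c3C2=O)c(=O)[nH]1`, 0.24 nM
compound 2 `COc1cc(C)[nH]c(=O)c1CN1CCc2c(Cl)cc(-c3c(C)noc3C)c(Cl)c2C1=O`, 0.15 nM
compound 3 `Cc1cc(C)c(CN2CCc3c(Cl)cc(C(CO)c4ccon4)c(Cl)c3C2=O)c(=O)[nH]1`, 360 nM; 24 nM (2 entries)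

Compound 1 has the higher of the two single numbers, with compound 2 the nearest; the two lie within the scatter of each other. Compound 3 stands apart, its several entries the several entries of compound 3 in this assay, 360 nM; 24 nM (2 entries) scattering widely. The next compound, compound 4 `Cc1cc(C)c(CN2CCc3c(Cl)cc([C@H](C)CO)c(Cl)c3C2=O)c(=O)[nH]1`, is not yet measured in this assay. It differs from compound 1 by a group of 4 heavy atoms (3 carbon, 1 oxygen; no ring) in place of a group of 8 heavy atoms (6 carbon, 2 oxygen; one five-membered non-aromatic ring with 1 hetero atom), on an aromatic carbon. Within the data shown here, no step between measured compounds covers this change. A step to a higher number, beyond the scatter, is expected from compound 1 to compound 4, as a 4.2-fold higher number from compound 1 to compound 4 (0.62 log units; beyond the scatter). Compound 4 is estimated at 1 nM, within 0.2 nM to 5 nM.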

Compound 4, inhibition constant: 17 nM
For compound 4 the middle estimate is 17-fold (1.23 log units) below the measured one, outside the stated range (above it).
By their numbers in this assay, from the lowest: compounds 2 and 1 (each within the scatter of the next); then compound 4.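

In this assay, 1-(hydroxymethyl)ethyl in place of the group of 8 heavy atoms with its five-membered non-aromatic ring gives a 71-fold higher number from compound 1 to compound 4 (1.85 log units; beyond the scatter). This position is therefore sensitive to this change, and the hydroxymethyl part alone does not retain the low number of compound 1. Nothing at hand accounts for the size of this step. Still open, as far as these compounds go, is whether the ring itself is needed or a longer open chain would serve as well. An amine or a carboxylic acid on the same carbon also remains to be placed in this series.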